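The source may report more compounds than this note shows. Statements on the series, on what has been measured and on what is new or still open speak of the compounds shown alone.

Within the data shown here, in a functional assay on HeLa cells (Homo sapiens) for antiproliferative activity, read by MTT assay, with a stated time of 72 h (a lower number here means a stronger inhibitor, a higher number a weaker inhibitor), compound 3 `COc1ncc(-c2ccc3c(c2)NC(=O)CO3)cc1NS(=O)(=O)c1ccc(F)cc1` gives 7110 nM, the lowest number measured so far. Compound 2 `COc1ccc(N2C(=O)COc3ccc(-c4ccc(O)cc4)cc32)cc1` gives 16400 nM, a higher number by more than the usual scatter. For compound 1 `O=C1COc2ccc(-c3cccc(NS(=O)(=O)c4ccc(F)cc4)c3)cc2N1` the result is a limit, > 40000 nM. Compound 4 `COc1ncc(-c2ccc3c(c2)N(c2ccc(F)cc2)C(=O)CO3)cc1NS(=O)(=O)c1ccc(F)cc1` differs from compound 3 in one place: 4-fluorophenyl in place of hydrogen on an amide-type nitrogen in a ring, with 4-fluorophenyl in place of hydrogen on an amide-type nitrogen in a ring. Among the measured compounds shown here, no measured pair shows this change alone, so the expectation rests on thin evidence. A step toward stronger inhibition in this assay, beyond the scatter, is still expected. The expected size is a 4.0-fold lower number from compound 3 to compound 4 (0.60 log units; beyond the scatter). For compound 4 the estimated value is 1800 nM, within an expected range of 200 nM to 12000 nM.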

Compound 4, half-maximal inhibitory concentration: 10500 nM
Estimate against measurement, compound 4: 5.8-fold (0.77 log units) below, within the range that was stated.
By their numbers in this assay, from the lowest: compounds 3, 4 and 2 (each within the scatter of the next, the first and the last beyond it). At a limit, above all of these: compound 1.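

In this assay, 4-fluorophenyl in place of hydrogen on the amide-type nitrogen gives a 1.5-fold higher number from compound 3 to compound 4 (0.17 log units; within the scatter), so this position accepts that whole aromatic ring with no change beyond the scatter. A single pair cannot show whether that holds for other groups here. Only compound 1 stands at a limit, so this step compares two true numbers: the limit of > 40000 nM in this assay, at which 1 of the 4 values shown sits.

Open, from the compounds shown here alone, is whether a chain ending in an amine or a carboxylic acid on this nitrogen would shift the number beyond the scatter, and in which direction.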